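The source may hold more compounds than are shown below. What is called first, only, known or untested is meant among the compounds shown, and "the series" means these compounds.

Of the compounds shown here, three sharing one core have been measured in an in vitro ADME assay on microsomes from liver (Mus musculus) for pharmacokinetics, read by LC-MS, with a stated time of 10 min, tested at 1 uM; a higher number here means faster removal of the compound, a lower number slower removal. There, compound 1 `CN1C[C@H](C(=O)Nc2ccc(C(F)(F)F)cc2)[C@@H](c2ccc(/C=C/C(=O)Nc3ccccc3N)cc2)C1` gives 23 mL/min/kg, compound 2 `CN1C[C@H](C(=O)Nc2ccc(Br)cc2)[C@@H](c2ccc(/C=C/C(=O)Nc3ccccc3N)cc2)C1` gives 16 mL/min/kg and compound 3 `CN1C[C@H](C(=O)Nc2ccc(F)cc2F)[C@@H](c2ccc(/C=C/C(=O)Nc3ccccc3N)cc2)C1` gives 27 mL/min/kg. Compound 3 therefore stands within the scatter of both of the others.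

Compound 4 `CN1C[C@H](C(=O)Nc2ccc(Cl)cn2)[C@@H](c2ccc(/C=C/C(=O)Nc3ccccc3N)cc2)C1` differs from compound 3 in one place: 5-chloropyridin-2-yl in place of 2,4-difluorophenyl on an amide-type nitrogen. In words, 5-chloropyridin-2-yl stands in place of 2,4-difluorophenyl on an amide-type nitrogen.

Among the measured compounds shown here, no measured step makes this exact exchange, but three exchange the aromatic group at that same place. They are a 1.4-fold lower number from compound 1 to compound 2 (0.16 log units; within the scatter), a 1.2-fold higher number from compound 1 to compound 3 (0.07 log units; within the scatter) and a 1.7-fold higher number from compound 2 to compound 3 (0.23 log units; within the scatter). Each of these steps lies within the scatter, so the measured compounds show no sensitivity of this assay to the group carried on that nitrogen. However, none of them carries a ring with a hetero atom there, so this part of the change remains untested and the range has to stay fairly wide.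

On the strength of these steps, no change beyond the scatter is expected, and the estimated step is a 1.2-fold lower number from compound 3 to compound 4 (0.09 log units; within the scatter). For compound 4 the expected value is 22 mL/min/kg, with an estimated range from 12 mL/min/kg to 40 mL/min/kg.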

Compound 4, clearance: 31 mL/min/kg
For compound 4 the middle estimate is 1.4-fold (0.15 log units) below the measured one; measured number inside the range.
By their numbers in this assay, from the lowest: compounds 2, 1, 3 and 4 (each within the scatter of the next).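

Placing 5-chloropyridin-2-yl on the amide-type nitrogen puts a ring with a hetero atom at this position, and in this assay the result is a 1.1-fold higher number from compound 3 to compound 4 (0.06 log units; within the scatter) as well as a 1.3-fold higher number from compound 1 to compound 4 (0.13 log units; within the scatter) and also a 1.9-fold higher number from compound 2 to compound 4 (0.29 log units; within the scatter) for this comparison. Among the compounds shown here, the question the earlier compounds left untested is thus answered for this one group: exchanging a six-membered aromatic ring of carbon only for one with a hetero atom and a hydrogen-bond acceptor gives no step beyond the scatter against any of the three others, so the lack of sensitivity at this nitrogen now covers all four groups. Nothing available here bears on the reason for this result.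

From the compounds shown here alone, all four compounds carry a six-membered aromatic ring with halogen or trifluoromethyl on that nitrogen, so it remains open whether a carboxylic acid or an aminomethyl group on the ring, or a longer alkyl chain in place of the ring, would also stay within the scatter. Going by these compounds, every other part of the molecule is the same in all four compounds, so whether this assay responds to a change elsewhere also remains open.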